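The compounds below may be only part of what the source reports. "The series", "measured", "known", "first", "only" and "open" are said of these compounds alone.

Measured compounds:
compound 1, `CCN(Cc1c[nH]nn1)C(=O)COc1ccc(C)cc1` — 31100 nM
compound 2, `CCN(Cc1cncs1)C(=O)COc1ccc(C)cc1` — 1100 nM
compound 3, `CCN(Cc1cccnc1)C(=O)COc1ccc(C)cc1` — 15400 nM

In an assay on HEK293 cells for agonist activity at transient receptor potential cation channel subfamily M member 8 (Homo sapiens), read by fluorescence and calcium flux, with a stated time of 15 min (a lower number here means that less compound is needed, a higher number that more compound is needed for the effect), compound 3 gives 15400 nM, the second highest of the three numbers. Its nearest neighbour is compound 1, separated by a 2.0-fold lower number from compound 1 to compound 3 (0.31 log units; beyond the scatter); compound 2 lies furthest away, separated by a 14-fold higher number from compound 2 to compound 3 (1.15 log units; beyond the scatter). The spread among the three is governed by the ring on the saturated chain carbon bound to the amide-type nitrogen, as the step of a 28-fold lower number from compound 1 to compound 2 (1.45 log units; beyond the scatter) shows.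

Compound 4, `CCN(Cc1ccncc1)C(=O)COc1ccc(C)cc1`, differs from compound 3 by pyridin-4-yl in place of pyridin-3-yl on a saturated chain carbon bound to an amide-type nitrogen. Among the compounds with values here, none of the measured steps bears directly on this change: each of them exchanges one ring for a different one, whereas here the same ring keeps its atoms and only the nitrogen moves. The data therefore give no direction, and a step within the usual scatter is expected. For compound 4 the estimate in this assay is 15000 nM, with a range from 4000 nM to 60000 nM. This estimate corresponds to an expected step of a 1.0-fold lower number from compound 3 to compound 4 (0.01 log units; within the scatter).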

Compound 4, half-maximal effective concentration: "not active" (no number reported)
Compound 4: no number reported; there is nothing to compare the estimate with.
By their numbers in this assay, from the lowest: compound 2; then compound 3; then compound 1.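

In this assay, within the data shown here, compound 4 is recorded as "not active", with no number, and no step from compound 3 to compound 4 can be read. No evidence bears on this result. The compounds shown leave open how pyridin-4-yl in place of pyridin-3-yl shifts the number.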